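Cyclobutyl amide in place of methoxycyclohexylmethyl on the core

The compounds below may be only part of what the source reports. "The series", "measured", "known", "first", "only" and "open" are said of these compounds alone.

The series is read in an assay on isolated protein for inhibition of protein kinase C theta type (Homo sapiens), read by TR-FRET, with a stated time of 2 h; on this read-out higher numbers stand for weaker inhibition and lower numbers for stronger inhibition. Compound 1 `CO[C@H]1CC[C@H](CNc2cc(NCc3cnccc3C(F)(F)F)ncc2C#N)CC1` gives 330 nM, the second highest of the three numbers; compound 3 `N#Cc1cnc(NCc2cncnc2-c2ccccc2)cc1N[C@H]1CC[C@@H](O)CC1` gives 90 nM, a gap beyond the scatter, and compound 2 `N#Cc1cnc(NCc2ccccc2C(F)(F)F)cc1N[C@H]1C[C@H](C(N)=O)C1` gives 5000 nM, also beyond the scatter. Compound 4 `CC1(C)[C@@H](C(N)=O)C[C@H]1Nc1cc(NCc2cnccc2C(F)(F)F)ncc1C#N` is not yet measured and differs from compound 1 only by 3-carbamoyl-2,2-dimethylcyclobutyl in place of (4-methoxycyclohexyl)methyl on a nitrogen on an aromatic ring. Among the measured compounds shown here, no measured pair shows this change on its own, but compound 2, which also carries a carbamoyl-bearing cyclobutyl on that nitrogen, holds the highest number in the set at 5000 nM. The expected step in this assay is therefore towards weaker inhibition and beyond the scatter, estimated as a 4.5-fold higher number from compound 1 to compound 4 (0.66 log units; beyond the scatter). Compound 4 is expected to give 1500 nM, within 400 nM to 6000 nM.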

Compound 4, half-maximal inhibitory concentration: 1.4 nM
Estimate against measurement, compound 4: 1100-fold (3.03 log units) above, and the stated range ends above it.
By their numbers in this assay, from the lowest: compound 4; then compound 3; then compound 1; then compound 2.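

In this assay, among the compounds shown here, this nitrogen substituent carries far more weight than the earlier compounds could show: 3-carbamoyl-2,2-dimethylcyclobutyl in place of (4-methoxycyclohexyl)methyl gives a 240-fold lower number from compound 1 to compound 4 (2.37 log units; beyond the scatter). With the rest of compound 1 kept, a carbamoyl-bearing cyclobutyl is thus compatible with strong inhibition at this position. No measurement shown accounts for the size of the step.

The compounds shown do not separate the contributions of the carbamoyl, the two ring methyl groups and the ring size. From the compounds shown here alone, whether a carboxylic acid or a methyl ester could stand in place of the carbamoyl also remains open.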